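From 4-Methoxyphenyl to 2-Bromophenyl on the Amine Nitrogen

The source may hold more compounds than are shown below. What is called first, only, known or untested is meant among the compounds shown, and "the series" means these compounds.

Of the compounds shown here, three sharing one core have been tested in a functional assay on MCF7 cells (Homo sapiens) for inhibition, read by MTT assay, with a stated time of 72 h, tested at 10 uM; a higher number here means more inhibition at the concentration tested (going by the name of the read-out), a lower number less inhibition. Compound 1 `CCOC(=O)C1=C(Nc2ccccc2)S/C(=C\c2cccc(C(=O)O)c2)C1=O` returns only a limit of the assay, < 10%. Compound 2 `CCOC(=O)C1=C(Nc2ccccc2)S/C(=C\c2cc(OC)c(O)c(OC)c2)C1=O` gives 12.9%. Compound 3 `CCOC(=O)C1=C(Nc2ccc(OC)cc2)S/C(=C\c2ccc[nH]2)C1=O` also returns only a limit, < 10%. Going by these compounds, two of the three results thus sit at the same limit, (the limit of < 10% in this assay, at which 2 of the 3 values shown sit), and compound 3 stands there, so its exact value is unknown and only its smallness is clear. Compound 4 `CCOC(=O)C1=C(Nc2ccccc2Br)S/C(=C\c2ccc[nH]2)C1=O` differs from compound 3 in one place: 2-bromophenyl in place of 4-methoxyphenyl on an amine nitrogen. Within the data shown here, no measured pair shows what this change does in this assay. The step from compound 3 to compound 4 is expected to be a step that the limit leaves unreadable from compound 3 to compound 4, none beyond the scatter. Compound 4 is estimated at 8%, between 0% and 25%.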

Compound 4, a percentage reported as inhibition, at one concentration (the size of the read-out at that concentration, not a potency): 29.4%
For compound 4 the middle estimate is 21.4 percentage points below the measured one; the measured number lies above the stated range.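

Replacing 4-methoxyphenyl with 2-bromophenyl on the amine nitrogen gives a number at least 19.4 percentage points higher from compound 3 to compound 4 (beyond the scatter) in this assay. Among these compounds, this is the first one-place comparison, and it shows that the group on this nitrogen can change the read-out. The true size of the step stays unknown because compound 3 rests on a limit of the assay: the limit of < 10% in this assay, at which 2 of the 4 values shown sit.

Still open, going by these compounds, is whether the bromine itself or its place on the ring carries the step. 2-Chlorophenyl and 4-bromophenyl on the core of compound 4 would bear on that question.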